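The compounds below may be only part of what the source reports. "The series", "measured", "known", "first", "only" and "open" are said of these compounds alone.

In an ADME assay on HEK293 cells (Homo sapiens) for cytotoxicity (on this read-out lower numbers stand for stronger inhibition and higher numbers for weaker inhibition), the series so far reads:
compound 1 `CCCCCCCCCCCCCCNC(=O)[C@H](CO)/N=C/c1cccc(OC)c1` gives 77300 nM
compound 2 `CCCCCCCCCCCCCCNC(=O)[C@H](CO)/N=C/c1ccc(OC)cc1` gives 81700 nM
compound 3 `CCCCCCCCCCCCCCNC(=O)[C@H](CO)/N=C/c1ccccc1[N+](=O)[O-]` gives 82600 nM

Compound 3 cannot be told apart from the other two, as a 1.0-fold higher number from compound 2 to compound 3 (0.00 log units; within the scatter) and a 1.1-fold higher number from compound 1 to compound 3 (0.03 log units; within the scatter) both show. Compound 4 `CCCCCCCCCCCCCCNC(=O)[C@H](CO)/N=C/c1ccc(Cl)cc1` carries 4-chlorophenyl in place of 2-nitrophenyl on a carbon with a double bond to nitrogen. The bearing steps are these same aryl exchanges, together with a 1.1-fold higher number from compound 1 to compound 2 (0.02 log units; within the scatter), and all three stay inside the scatter. Going by the values given here, none of the measured compounds carries chlorine, so the guide is indirect. The expected change is a 1.1-fold lower number from compound 3 to compound 4 (0.04 log units; within the scatter), no larger than the scatter. In this assay compound 4 is estimated at 75000 nM, with an expected range from 40000 nM to 130000 nM.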

Compound 4, half-maximal inhibitory concentration: 77700 nM
Compound 4: the middle estimate sits 1.0-fold (0.02 log units) below what was measured, within the range that was stated.
By their numbers in this assay, from the lowest: compounds 1, 4, 2 and 3 (each within the scatter of the next).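

In this assay, chlorine enters the series as 4-chlorophenyl on a carbon with a double bond to nitrogen, and the exchange for 2-nitrophenyl stays within the scatter, with a 1.1-fold lower number from compound 3 to compound 4 (0.03 log units; within the scatter). Chloro in place of methoxy on an aromatic carbon also stays within it, with a 1.1-fold lower number from compound 2 to compound 4 (0.02 log units; within the scatter), as does the exchange for 3-methoxyphenyl, with a 1.0-fold higher number from compound 1 to compound 4 (0.00 log units; within the scatter). No available data explain this flat reading. Open, as far as these compounds go, is whether an amine or a carboxylic acid on the phenyl ring would move the number beyond the scatter. From the compounds shown here alone, a shorter chain in place of the long one on the amide also remains open.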